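A Second Chloro on a Pair at the Assay Limit

This account rests on a few compounds, and the source may have more. Where it says the series, first, only, none or still open, it means among the compounds named here.

compound 1, `CNC(=O)c1ccc(-c2ccccc2Cl)c(N)n1`: > 32000 nM
compound 2, `CNC(=O)c1ccc(-c2cccc(Cl)c2)c(N)n1`: > 32000 nM

In an assay on HEK293 cells for inhibition of sodium channel protein type 10 subunit alpha (Homo sapiens), read by fluorescence (a higher number here means a weaker inhibitor, a lower number a stronger inhibitor), compound 1 gives only a limit, > 32000 nM. Compound 2 also gives only a limit in this assay, > 32000 nM. Compound 2 thus stands at the limit of > 32000 nM in this assay, at which 2 of the 2 values shown sit, and compound 1 stands with it. Compound 3, `CNC(=O)c1ccc(-c2cc(Cl)cc(Cl)c2)c(N)n1`, differs from compound 2 by chloro in place of hydrogen on an aromatic carbon. No measured step of this kind is available among these compounds. Because compound 2 sits at the limit of > 32000 nM in this assay, at which 2 of the 2 values shown sit, the step from compound 2 to compound 3 is expected to be none beyond the scatter, a number no higher from compound 2 to compound 3 (the limit leaves the size open). Compound 3 is therefore estimated at 32000 nM, with a range from 8000 nM to 100000 nM.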

Compound 3, half-maximal inhibitory concentration: > 32000 nM
Compound 3 was reported as a limit; the forecaster's own chance of this, stated with the estimate: 75%; the middle value sits exactly at the limit.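

Within the data shown here, compound 3 gives only a limit in this assay, > 32000 nM, so no step from compound 2 to compound 3 can be read. The compounds shown leave open how strongly any of them inhibits, and whether chloro in place of hydrogen matters at all.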